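This account rests on a few compounds, and the source may have more. Where it says the series, first, only, none or still open, it means among the compounds named here.

Measured values in a functional assay on MCF7 cells (Homo sapiens) for inhibition, read by MTT assay, with a stated time of 72 h; a lower number here means a stronger inhibitor of growth, a higher number a weaker inhibitor of growth:
Compound 1, `O=S(=O)(NCCNCc1cccc2ccccc12)c1cc(C(F)(F)F)cc(C(F)(F)F)c1`, gives 18000 nM.
Compound 2, `CC(C)(C)c1ccc(CNCCCNS(=O)(=O)c2cc(C(F)(F)F)cc(C(F)(F)F)c2)cc1`, gives 2100 nM.
Compound 3, `O=S(=O)(NCCCNCc1ccc(C(F)(F)F)cc1)c1cc(C(F)(F)F)cc(C(F)(F)F)c1`, gives 1400 nM.

Compound 3 has the lowest of the three numbers in this assay, but its nearest neighbour, compound 2, sits within the scatter of it, so no order can be drawn between those two; only compound 1, which differs from compound 3 in more than one place, is clearly apart, with the higher number. Compound 4, `COc1ccc(CNCCCNS(=O)(=O)c2cc(C(F)(F)F)cc(C(F)(F)F)c2)cc1`, has not yet been measured in this assay. It differs from compound 3 by methoxy in place of trifluoromethyl on an aromatic carbon. Among the compounds with values here, the only measured step at this carbon is a 1.5-fold lower number from compound 2 to compound 3 (0.18 log units; within the scatter), which exchanged one group for another there without leaving the scatter. Nothing measured here carries an oxygen-bearing group at that carbon, so the expectation rests on that single step alone and is for little change in either direction. Compound 4 is therefore expected to give about 2000 nM in this assay, with a range from 800 nM to 5000 nM. The expected step of a 1.4-fold higher number from compound 3 to compound 4 (0.15 log units; within the scatter) is not one that should stand beyond the scatter.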

Compound 4, concentration for 50% growth inhibition: 2500 nM
Beside the measured number, compound 4's estimate is 1.3-fold (0.10 log units) below it, within the range that was stated.
By their numbers in this assay, from the lowest: compounds 3, 2 and 4 (each within the scatter of the next); then compound 1.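

In this assay, within the data shown here, the first oxygen-bearing group at this aromatic carbon stays within the scatter of both earlier groups, with a 1.8-fold higher number from compound 3 to compound 4 (0.25 log units; within the scatter) and a 1.2-fold higher number from compound 2 to compound 4 (0.08 log units; within the scatter) as the two steps. The earlier compounds had shown this only for tert-butyl and trifluoromethyl; now methoxy, with its hydrogen-bond acceptor, also gives a number that cannot be ordered against theirs, so compound 2, compound 3 and compound 4 form one group in this assay. Nothing measured here explains why these exchanges stay so small.

From the compounds shown here alone, it remains open whether an amine or a carboxylic acid on this aromatic carbon would give a step beyond the scatter. Compound 1 differs from the others in more than one place, so the parts of that difference cannot be separated.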